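Chloro for Methoxy on the Pendant Phenyl of Compound 2

This account rests on a few compounds, and the source may have more. Where it says the series, first, only, none or still open, it means among the compounds named here.

The measured compounds and their values:
Compound 1, `COc1ccc(C2=NN(C3=NC(=O)/C(=C4\C(=O)Nc5ccccc54)S3)C(c3ccc(OC)cc3)C2)cc1`, gives 81500 nM.
Compound 2, `COc1ccc(C2CC(c3ccc4ccccc4c3)=NN2C2=NC(=O)/C(=C3\C(=O)Nc4ccccc43)S2)cc1`, gives 5960 nM.
Compound 3, `COc1ccc(C2CC(c3ccc4ccccc4c3)=NN2C2=NC(=O)/C(=C3\C(=O)Nc4ccc(Br)cc43)S2)cc1`, gives 61 nM.

These three were tested in a functional assay on cells (Cancer cell lines, Homo sapiens) for cytotoxicity, read by sulforhodamine B assay, with a stated time of 48 h; on this read-out higher numbers stand for weaker inhibition of growth and lower numbers for stronger inhibition of growth. Compound 2 holds the middle place among them: its nearest neighbour is compound 1, and the step of a 14-fold lower number from compound 1 to compound 2 (1.14 log units; beyond the scatter) set them apart; its furthest neighbour is compound 3, reached through the step of a 98-fold lower number from compound 2 to compound 3 (1.99 log units; beyond the scatter).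

Compound 4, `O=C1N=C(N2N=C(c3ccc4ccccc4c3)CC2c2ccc(Cl)cc2)S/C1=C1/C(=O)Nc2ccccc21`, has not yet been measured in this assay. It differs from compound 2 in a single place: chloro in place of methoxy on an aromatic carbon. For the measured compounds named here, no measured step concerns this exact change. The step of a 14-fold lower number from compound 1 to compound 2 (1.14 log units; beyond the scatter) swaps a whole aryl group on a different carbon, and the step of a 98-fold lower number from compound 2 to compound 3 (1.99 log units; beyond the scatter) adds a halogen, but on the other aromatic ring of the shared core, not on the ring that carries the methoxy. Neither gives a direct reading of what chloro in place of methoxy, para to a large group, will do. Both of the known steps were large, which shows this series responds strongly to small edits, but their direction here cannot be inferred. Compound 4 is therefore expected to show only a modest change, a 1.7-fold lower number from compound 2 to compound 4 (0.23 log units; within the scatter), with wide uncertainty.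

Compound 4 is estimated at 3500 nM, within a range from 700 nM to 18000 nM.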

Compound 4, concentration for 50% growth inhibition: 740 nM
For compound 4 the middle estimate is 4.7-fold (0.67 log units) above the measured one; measured number inside the range.
By their numbers in this assay, from the lowest: compound 3; then compound 4; then compound 2; then compound 1.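

In this assay, the ring carrying the methoxy of compound 2 proves responsive to a single edit: the step of an 8.1-fold lower number from compound 2 to compound 4 (0.91 log units; beyond the scatter) exchanges 4-methoxyphenyl for 4-chlorophenyl and lies beyond the scatter. For the compounds shown here, the earlier steps had read only the exchange of a whole aryl group on another carbon and a bromo on the other aromatic ring, so this is the first reading at this position, and it shows that growth inhibition does not depend on keeping the methoxy there. No available evidence accounts for the size or direction of this step.

The compounds shown do not separate the loss of the methoxy from the arrival of the chloro, a question that hydrogen, fluoro, bromo or an amine at the same place could begin to answer. They also leave open whether the chloro of compound 4 and the bromo of compound 3, which sit on different rings, would add up when carried together on the shared core.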